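The source may report more compounds than this note shows. Statements on the series, on what has been measured and on what is new or still open speak of the compounds shown alone.

Working notes on the series, read in an ADME assay on microsomes from liver (Homo sapiens) for metabolic stability; on this read-out higher numbers stand for a longer-lived compound and lower numbers for a shorter-lived compound: compound 1 `COc1cc(OCc2cccc(-c3ccc(OC)nc3)c2)c2cc(-c3cn4nc(OC)sc4n3)oc2c1` gives 0.733 h, compound 2 `COc1cc(OCc2cccc(-c3ccc(C#N)cn3)c2)c2cc(-c3cn4nc(OC)sc4n3)oc2c1` gives 1.57 h, and compound 3 `COc1cc(OCc2cccc(-c3cnc(OC)cn3)c2)c2cc(-c3cn4nc(OC)sc4n3)oc2c1` gives 1.48 h. Compound 3 thus sits in the upper pair of the three, within the scatter of compound 2 and clear of compound 1. Compound 4 `COc1cc(OCc2cccc(-c3cncnc3)c2)c2cc(-c3cn4nc(OC)sc4n3)oc2c1` carries the change (pyrimidin-5-yl in place of 5-methoxypyrazin-2-yl on an aromatic carbon), pyrimidin-5-yl in place of 5-methoxypyrazin-2-yl on an aromatic carbon. Three measured steps exchange the group at this place: a 2.1-fold higher number from compound 1 to compound 2 (0.33 log units; beyond the scatter) and a 2.0-fold higher number from compound 1 to compound 3 (0.31 log units; beyond the scatter) are modest, while a 1.1-fold lower number from compound 2 to compound 3 (0.03 log units; within the scatter) stays within the scatter. None contains pyrimidin-5-yl, so no step beyond the scatter is expected. The expected change is a 1.1-fold lower number from compound 3 to compound 4 (0.06 log units; within the scatter). For compound 4 the estimate is 1.3 h, with an expected range of 0.65 h to 2.6 h.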

Compound 4, half-life: 0.117 h
Compound 4: the middle estimate sits 11-fold (1.05 log units) above what was measured; the measured number lies below the stated range.
By their numbers in this assay, from the lowest: compound 4; then compound 1; then compounds 3 and 2 (each within the scatter of the next).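

The group at this place matters far more in this assay than the earlier exchanges showed: pyrimidin-5-yl brings a 13-fold lower number from compound 3 to compound 4 (1.10 log units; beyond the scatter) and a 13-fold lower number from compound 2 to compound 4 (1.13 log units; beyond the scatter) and also a 6.3-fold lower number from compound 1 to compound 4 (0.80 log units; beyond the scatter) while the three substituted rings stay much closer together. Compound 4, whose ring alone carries no substituent, stands lowest of the four, beyond the scatter of each other compound. Nothing available explains this drop. On these data alone, whether the unsubstituted ring or the ring nitrogen pattern drives it stays open. A methoxy group or an amine on the pyrimidine ring, or a plain phenyl ring, would separate the two.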